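The compounds below may be only part of what the source reports. "The series", "measured", "known", "first", "only" and "open" are said of these compounds alone.

Working notes on the series, read in an ADME assay on MT4 cells (Homo sapiens) for cytotoxicity; a lower number here means that less compound is tolerated, a higher number that more compound is tolerated. Compound 1 (`Cc1cccc(S(=O)(=O)n2c(=O)[nH]c3ccc(Cl)cc32)c1`) is reported as > 307000 nM, which is a limit of the assay and not a number. Compound 2 (`Cc1ccc(S(=O)(=O)n2c(=O)[nH]c3ccc(Cl)cc32)cc1`) gives 134000 nM. Among the measured compounds shown here, the one measured step between close neighbours is an at least 2.2-fold lower number from compound 1 to compound 2 (0.36 log units; beyond the scatter). Its size is only a bound because of the limit of > 307000 nM in this assay, at which 1 of the 3 values shown sits. Compound 3 (`O=c1[nH]c2ccc(Cl)cc2n1S(=O)(=O)c1cc(C(F)(F)F)cc(C(F)(F)F)c1`) gives 32300 nM, the lowest number in the set and beyond the scatter from the value of compound 2.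

Compound 4 (`O=c1[nH]c2ccc(Cl)cc2n1S(=O)(=O)c1cccc(C(F)(F)F)c1`) differs from compound 3 by hydrogen in place of trifluoromethyl on an aromatic carbon. For the measured compounds named here, no measured step makes this change directly. The step from compound 1 to compound 2 bears on it only loosely, showing that a small edit to the same aryl group can move the number beyond the scatter. The other guide is the gap between compound 3 at 32300 nM and compound 2 at 134000 nM. Losing one trifluoromethyl should therefore carry the number part of the way towards the methyl compounds. The expected change is a 2.8-fold higher number from compound 3 to compound 4 (0.45 log units; beyond the scatter), towards a higher number and beyond the scatter. For compound 4 the estimated value is 90000 nM, with an expected range of 35000 nM to 250000 nM.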

Compound 4, half-maximal cytotoxic concentration: > 331000 nM
Compound 4 was reported as a limit (the forecaster's own chance of this, stated with the estimate: 25%); at least 3.6-fold (0.56 log units) between middle value and limit.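

In this assay, hydrogen in place of trifluoromethyl on an aromatic carbon, meta to a trifluoromethyl group, gives an at least 10-fold higher number from compound 3 to compound 4 (1.01 log units; beyond the scatter). Compound 4 gives > 331000 nM, which is a limit of the assay and not a number. Within this pair, the low number of compound 3 therefore depends on the trifluoromethyl group at this position, and the single remaining trifluoromethyl group of compound 4 does not bring the number down to a measurable value, although the size of the step is only a bound because of this limit: the limit of > 331000 nM in this assay, at which 1 of the 4 values shown sits.

The step from compound 1 to compound 4 cannot be read, as both values are limits, so the compounds shown do not order methyl and trifluoromethyl at that place. On these data alone, it also remains open whether another group at the position that separates compound 3 from compound 4, such as a chlorine atom, a nitrile or an amine, would lower the number as trifluoromethyl does.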